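Cyclohexyl on the aromatic nitrogen of compound 2

A few compounds are considered here, and "the series" means these few. Any claim that something is new, unique, unknown or untested is made for them only; others in the source may bear on it.

In an ADME assay on BHK-21 cells (Mesocricetus auratus) for cytotoxicity, read by MTT assay (on this read-out lower numbers stand for higher toxicity in this test and higher numbers for lower toxicity in this test), compound 1 `CC(=O)c1ccc2[nH]c(-c3ccc(Cl)cc3)nc2c1` gives > 100000 nM, a limit of the assay. Compound 2 `CC(=O)c1ccc2[nH]c(-c3ccc(C(F)(F)F)cc3)nc2c1` gives > 100000 nM, also a limit and not a number. For compound 3 `C/C(=N\O)c1ccc2[nH]c(-c3ccc(C(F)(F)F)cc3)nc2c1` the result reads "not determined" (no result reported). For the measured compounds named here, the series so far offers only (the limit of > 100000 nM in this assay, at which 2 of the 3 values shown sit). Going by the values given here, the one measured step is a step that the two limits leave unreadable from compound 1 to compound 2, which gives no size to carry over.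

Compound 4 `CC(=O)c1ccc2c(c1)nc(-c1ccc(C(F)(F)F)cc1)n2C1CCCCC1` differs from compound 2 at one place, next to the ring atom that bears a large group: cyclohexyl in place of hydrogen on an aromatic nitrogen. Among the compounds with values here, no measured step covers this change, so only a modest expected step of an at least 1.4-fold lower number from compound 2 to compound 4 (0.15 log units; that floor lies within the scatter) is estimated, toward lower numbers and with low confidence. For compound 4 the estimated value is 70000 nM, with an expected range of 25000 nM to 100000 nM.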

Compound 4, half-maximal cytotoxic concentration: 33000 nM
Compound 4: the middle estimate sits 2.1-fold (0.33 log units) above what was measured, and the stated range covers the measured number.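

Placing cyclohexyl on the aromatic nitrogen gives the first step in this assay with a readable size, toward higher toxicity in this test: an at least 3.0-fold lower number from compound 2 to compound 4 (0.48 log units; beyond the scatter). Compound 2 gives > 100000 nM, a limit of the assay, so this step has only a floor: the limit of > 100000 nM in this assay, at which 2 of the 4 values shown sit. The chloro to trifluoromethyl step cannot be read, so this position is the only place in the series with a readable change.

Going by these compounds, whether the step is specific to cyclohexyl remains open. Methyl, a longer chain such as n-butyl, or a cyclohexyl carrying an amine on this nitrogen would test that.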